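The source may hold more compounds than are shown below. What is called first, only, known or untested is meant among the compounds shown, and "the series" means these compounds.

Compound 1 `Nc1cccc(/C=C/c2ccccc2O)c1`, compound 2 `COc1cccc(/C=C/c2ccccc2O)c1` and compound 3 `Nc1cccc(/C=C/c2cccc(O)c2)c1` share a core and have been tested in a functional assay on HT-29 cells (Homo sapiens) for inhibition, read by MTT assay, with a stated time of 2 days; on this read-out lower numbers stand for stronger inhibition and higher numbers for weaker inhibition. In this assay compound 1 gives 30.4 ug/mL, compound 2 gives 26 ug/mL and compound 3 gives 43 ug/mL. Compound 2 differs from compound 1 by methoxy in place of amino on an aromatic carbon, a change that made a step of a 1.2-fold lower number from compound 1 to compound 2 (0.07 log units; within the scatter). Compound 3 has the same atoms as compound 1 joined differently, and the difference between the two cores is not broken down here. Compound 4 `COc1cccc(/C=C/c2cccc(O)c2)c1`, not yet measured, differs from compound 3 by methoxy in place of amino on an aromatic carbon, the same change at the same place. Because that change gave a 1.2-fold lower number from compound 1 to compound 2 (0.07 log units; within the scatter), the step from compound 3 to compound 4 is expected to be a 1.2-fold lower number from compound 3 to compound 4 (0.08 log units; within the scatter). Compound 4 is therefore estimated at 36 ug/mL, likely between 20 ug/mL and 65 ug/mL.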

Compound 4, half-maximal inhibitory concentration: 11.5 ug/mL
Compound 4: middle estimate off by 3.1-fold (0.50 log units), on the high side; measured number outside the range, below it.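

In this assay methoxy in place of amino on an aromatic carbon gave a 3.7-fold lower number from compound 3 to compound 4 (0.57 log units; beyond the scatter) and so did not repeat the size of the step seen on the core of compound 1: the same change on two cores in this assay, a 1.2-fold lower number (0.07 log units; within the scatter) from compound 1 to compound 2 and a 3.7-fold lower number (0.57 log units; beyond the scatter) from compound 3 to compound 4, 3.2-fold (0.50 log units) apart, beyond the scatter of two such steps. The size of this change therefore did not carry over from one core to the other, so a step measured on one of these cores is a poor guide to the same step on the other. These two pairs do not show why the cores differ, nor how the change would behave on any further core.

The compounds shown leave open whether other groups in place of amino, such as ethoxy or a carboxylic acid, would also differ between the two cores.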